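Chloro addition on a two-member sulfonamide series

The source may hold more compounds than are shown below. What is called first, only, known or untested is meant among the compounds shown, and "the series" means these compounds.

In a functional assay on KB cells (Homo sapiens) for antiproliferative activity, read by colorimetric assay and MTT assay (on this read-out higher numbers stand for weaker inhibition and lower numbers for stronger inhibition), compound 1 `N#Cc1ccc(S(=O)(=O)Nc2cccc3c(Cl)c[nH]c23)cc1` gives 11 ug/mL. Compound 2 `N#Cc1ccc(S(=O)(=O)Nc2ccc(Cl)c3cc[nH]c23)cc1` gives 15 ug/mL, which lies within the usual scatter of the number for compound 1, so the two cannot be told apart on this read-out. For the measured compounds named here, compound 2 therefore stands level with the only other measured member of the series.

Compound 3 `N#Cc1ccc(S(=O)(=O)Nc2ccc(Cl)c3c(Cl)c[nH]c23)cc1` departs from compound 2 by one change, chloro in place of hydrogen on an aromatic carbon. Going by the values given here, no measured step shows what such a change does, so the forecast is a judgement with a wide range. In this assay, a modest move towards a lower number is expected, and it may not clear the scatter. The expected change is a 1.9-fold lower number from compound 2 to compound 3 (0.27 log units; within the scatter). For compound 3 the estimated value is 8 ug/mL, with an expected range of 3 ug/mL to 20 ug/mL.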

Compound 3, half-maximal inhibitory concentration: 13 ug/mL
For compound 3 the middle estimate is 1.6-fold (0.21 log units) below the measured one; low and high end bracket the measured number.
By their numbers in this assay, from the lowest: compounds 1, 3 and 2 (each within the scatter of the next).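

In this assay, chloro in place of hydrogen on an aromatic carbon of the five-membered aromatic ring, two ring bonds from the ring nitrogen, gives a 1.2-fold lower number from compound 2 to compound 3 (0.06 log units; within the scatter). The step to the same compound from the other side, chloro in place of hydrogen at the other chlorinated carbon, gives a 1.2-fold higher number from compound 1 to compound 3 (0.07 log units; within the scatter), so neither chloro addition separates from the scatter, and compound 3, with both chloro groups, stands level with each compound carrying one. Nothing at hand offers an explanation for this result.

From the compounds shown here alone, whether any group other than chloro on this carbon, such as an amine or a methoxy group, would move the number beyond the scatter stays open. Going by these compounds, all three compounds carry the nitrile, so the effect of replacing it, for instance with a carboxylic acid, also stays open.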